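From Fluoro to Trifluoromethyl on a Shared Core

The source may report more compounds than this note shows. Statements on the series, on what has been measured and on what is new or still open speak of the compounds shown alone.

Measured in an ADME assay on MT4 cells (Homo sapiens) for cytotoxicity, read by MTT assay, with a stated time of 4 days (on this read-out higher numbers stand for lower toxicity in this test and lower numbers for higher toxicity in this test), so far:
Compound 1 `CC(=O)Nc1ccc(O)c(C(=O)/C=C/c2ccccc2)c1` gives 49400 nM on this read-out
Compound 2 `COc1cccc(/C=C/C(=O)c2cc(NC(C)=O)ccc2O)c1` gives 40000 nM on this read-out
Compound 3 `CC(=O)Nc1ccc(O)c(C(=O)/C=C/c2cccc(F)c2)c1` gives 30100 nM on this read-out

Compound 3 stands within the scatter of both other compounds, so the three numbers cannot be put in any order. Compound 4 `CC(=O)Nc1ccc(O)c(C(=O)/C=C/c2cccc(C(F)(F)F)c2)c1` has trifluoromethyl in place of fluoro on an aromatic carbon. The two exchanges that introduce fluoro give a 1.6-fold lower number from compound 1 to compound 3 (0.22 log units; within the scatter) and a 1.3-fold lower number from compound 2 to compound 3 (0.12 log units; within the scatter) while methoxy in place of hydrogen gives a 1.2-fold lower number from compound 1 to compound 2 (0.09 log units; within the scatter) and all three stay within the scatter. Within the data shown here, no measured compound carries trifluoromethyl, so this exchange has no direct measured precedent. On these small steps, no change beyond the scatter is expected in this assay and no firm direction can be given. The estimated step is a 1.1-fold lower number from compound 3 to compound 4 (0.03 log units; within the scatter) and remains only an expectation. Compound 4 is expected at 28000 nM with 14000 nM and 55000 nM as the estimated ends of its range.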

Compound 4, half-maximal cytotoxic concentration: 32100 nM
For compound 4 the middle estimate is 1.1-fold (0.06 log units) below the measured one, within the range that was stated.
By their numbers in this assay, from the lowest: compounds 3, 4, 2 and 1 (each within the scatter of the next).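

In this assay, trifluoromethyl, with 4 heavy atoms against 1 for fluoro, sits on the same aromatic carbon, meta to a large group, and the results give a 1.1-fold higher number from compound 3 to compound 4 (0.03 log units; within the scatter) as well as a 1.2-fold lower number from compound 2 to compound 4 (0.10 log units; within the scatter) and a 1.5-fold lower number from compound 1 to compound 4 (0.19 log units; within the scatter) with no comparison leaving the scatter. Hydrogen, methoxy, fluoro and trifluoromethyl at this position therefore cannot be told apart on this read-out, so a larger fluorinated group adds no separation that the smaller exchanges had failed to show. No supporting measurement is available to explain this result.

The compounds shown leave open whether an amine or a carboxylic acid at this position could give a difference beyond the scatter. They also leave open whether a longer chain in place of the acetyl group on the shared core could do so.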